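This account rests on a few compounds, and the source may have more. Where it says the series, first, only, none or still open, it means among the compounds named here.

Measured compounds:
Compound 1 `Cc1ccc(C(=O)c2ccn(-c3ccc4c(c3)B(O)OC4)c2)cc1`; in an ADME assay on L929 cells (Mus musculus) for cytotoxicity, read by resazurin assay, with a stated time of 72 h (on this read-out lower numbers stand for stronger inhibition and higher numbers for weaker inhibition), compound 1 gives > 10 ug/mL, which is a limit of the assay and not a number.
Compound 2 `O=C(c1ccc(CO)cc1)c1ccn(-c2ccc3c(c2)B(O)OC3)c1`; in this assay compound 2 gives 9.31 ug/mL.

Compound 2 thus holds the only number shown in this assay, the other value being a limit. Among the compounds with values here, the one measured step, hydroxy in place of hydrogen on a saturated chain carbon bound to an aromatic carbon, gave an at least 1.0-fold lower number from compound 1 to compound 2 (0.03 log units; that floor lies within the scatter), and that floor lies within the scatter; it rests on (the limit of > 10 ug/mL in this assay, at which 1 of the 2 values shown sits).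

Compound 3 `Nc1ccc(C(=O)c2ccn(-c3ccc4c(c3)B(O)OC4)c2)cc1` differs from compound 2 by amino in place of hydroxymethyl on an aromatic carbon. Within the data shown here, the only step measured so far exchanged a hydrogen for a hydroxy and stayed within the scatter, so there is no measured step that points toward a shift of any size in this assay for this exchange of one polar group for another. Compound 3 is therefore expected to give about 10 ug/mL, with a range from 5 ug/mL to 20 ug/mL, and a limit is as likely as a number. For compound 3 this estimate means a 1.1-fold higher number from compound 2 to compound 3 (0.03 log units; within the scatter), expected to stay within the scatter.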

Compound 3, half-maximal inhibitory concentration: 3.9 ug/mL
Compound 3: the middle estimate sits 2.6-fold (0.41 log units) above what was measured, and the stated range ends above it.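

In this assay the aromatic carbon para to a large group now shows that a change there can move the number beyond the scatter: amino in place of hydroxymethyl gave a 2.4-fold lower number from compound 2 to compound 3 (0.38 log units; beyond the scatter) and thus went past what the earlier hydroxy step could show, since that step offered only a floor within the scatter. Amino in place of methyl at this same carbon gave an at least 2.5-fold lower number from compound 1 to compound 3 (0.40 log units; beyond the scatter) and so points the same way from a second starting compound, with amino the group in common. That second step is only a floor, since compound 1 holds a limit of the assay and not a number: the limit of > 10 ug/mL in this assay, at which 1 of the 3 values shown sits.

The compounds shown leave open whether the lower number belongs to amino alone or would also come with a dimethylamino group, an acetamide or a carboxylic acid on this carbon. They also leave open where plain hydrogen on this carbon would stand, and whether amino at other places on the same ring would give a similar step.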